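Amide nitrogen substituent within the shared core series

The compounds below may be only part of what the source reports. "The series", "measured", "known", "first", "only" and "open" are said of these compounds alone.

Measured so far in an assay on HL-60 cells for agonist activity at vitamin D3 receptor (Homo sapiens), read by microscopy, with a stated time of 96 h; on this read-out lower numbers stand for an effect already at smaller amounts and higher numbers for an effect only at larger amounts of compound:
Compound 1 `CCOC(=O)CN(C)C(=O)c1ccc(C(CC)(CC)c2ccc(OCC(=O)C(C)(C)C)c(C)c2)n1CC` gives > 50000 nM, which is a limit of the assay and not a number.
Compound 2 `CCn1c(C(=O)NCC(OC)OC)ccc1C(CC)(CC)c1ccc(OCC(=O)C(C)(C)C)c(C)c1` gives 130 nM.
Compound 3 `CCOC(=O)CN(C)C(=O)c1ccc(C(CC)(CC)c2ccc(OCC(O)C(C)(C)C)c(C)c2)n1CC` gives 210 nM.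

Compound 3 holds the highest of the two numbers, but its nearest neighbour, compound 2, sits within the scatter, so no order is drawn between them. Compound 4 `CCn1c(C(=O)N(C)c2ccccc2)ccc1C(CC)(CC)c1ccc(OCC(O)C(C)(C)C)c(C)c1` differs from compound 3 by phenyl in place of (ethoxycarbonyl)methyl on an amide-type nitrogen.

Among the compounds with values here, two measured steps touch the series. The step of an at least 380-fold lower number from compound 1 to compound 2 (2.58 log units; beyond the scatter) alters the substituent on the carbonyl carbon, the same region as the change to compound 4, and begins from the limit (the limit of > 50000 nM in this assay, at which 1 of the 3 values shown sits), so its true size is not known. The step of an at least 230-fold lower number from compound 1 to compound 3 (2.37 log units; beyond the scatter) alters the saturated chain carbon bound to the oxygen on the aromatic ring, a part left unchanged in compound 4. Neither step replaces the (ethoxycarbonyl)methyl with a phenyl, so the direction for compound 4 is not indicated by the data; the amide region has shown that it can move values strongly.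

Compound 4 is therefore expected to give 200 nM, with a range from 40 nM to 1500 nM, meaning an estimated step of a 1.1-fold lower number from compound 3 to compound 4 (0.02 log units; within the scatter) that may not pass beyond the scatter.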

Compound 4, half-maximal effective concentration: 6400 nM
Estimate against measurement, compound 4: 32-fold (1.51 log units) below, outside the stated range (above it).
By their numbers in this assay, from the lowest: compounds 2 and 3 (each within the scatter of the next); then compound 4. At a limit, above all of these: compound 1.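

In this assay, phenyl in place of (ethoxycarbonyl)methyl on the amide-type nitrogen gives a 30-fold higher number from compound 3 to compound 4 (1.48 log units; beyond the scatter), so this position responds strongly to the identity of the group even when the heavy-atom count stays at 6. Within the data shown here, the earlier steps in this region both started from compound 1, whose > 50000 nM is a limit of the assay and not a number; this step is the first here with measured numbers at both ends. The change replaces a chain with no ring and 2 hydrogen-bond acceptors by a six-membered aromatic ring with 0 hydrogen-bond acceptors, and nothing measured here ties the step to any one of these differences.

From the compounds shown here alone, a single step cannot show whether the loss comes from removing the ester or from introducing the aromatic ring, so it remains open whether a carboxylic acid in place of the ester, a benzyl group or a pyridine ring on this nitrogen would track compound 3 or compound 4. Compound 2 differs from compound 4 in more than one place, so the effect of the 1-hydroxy-2,2-dimethylpropyl group alongside the methyl(phenyl)carbamoyl group also remains unresolved.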